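Triazole substituent swap in the lactone series

The source may report more compounds than this note shows. Statements on the series, on what has been measured and on what is new or still open speak of the compounds shown alone.

The shared core of compound 1 `Cc1ccc(S(=O)(=O)NCc2cn(C[C@H](O)[C@H]3OC(=O)C(OCc4ccccc4)=C3OCc3ccccc3)nn2)cc1` carries a triazole-linked side chain; in a functional assay on HCT-116 cells (Homo sapiens) for antiproliferative activity, read by MTT assay, with a stated time of 72 h (on this read-out higher numbers stand for weaker inhibition and lower numbers for stronger inhibition), compound 1 gives 13100 nM. Compound 2 `O=C1O[C@H]([C@@H](O)Cn2cc(-c3cc(C(F)(F)F)cc(C(F)(F)F)c3)nn2)C(OCc2ccccc2)=C1OCc1ccccc1` gives 57200 nM in this assay. Compound 3 `COc1ccccc1-c1cn(C/C=C2\OC(=O)C(OCc3ccccc3)=C2OCc2ccccc2)nn1` returns only a limit in this assay, > 100000 nM; this is the limit of > 100000 nM in this assay, at which 1 of the 3 values shown sits. Among the two numbers shown, compound 1 stands lowest, with compound 2 beyond the scatter of it.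

Compound 4 `CCCCCc1ccc(-c2cn(C[C@H](O)[C@H]3OC(=O)C(OCc4ccccc4)=C3OCc3ccccc3)nn2)cc1` is not yet measured. It differs from compound 1 by 4-pentylphenyl in place of (((4-methylphenyl)sulfonyl)amino)methyl on an aromatic carbon. Among the compounds with values here, no step between measured compounds matches this change. Compound 2 also bears an aryl group on that same ring carbon and gives 57200 nM, so the expected direction is toward a higher number than compound 1. The step of a 2.3-fold higher number from compound 1 to compound 4 (0.36 log units; beyond the scatter) is the estimate, of moderate size, beyond the scatter. Compound 4 is expected to give about 30000 nM, with a range from 8000 nM to 100000 nM in this assay.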

Compound 4, half-maximal inhibitory concentration: 13800 nM
For compound 4 the middle estimate is 2.2-fold (0.34 log units) above the measured one, and the stated range covers the measured number.
By their numbers in this assay, from the lowest: compounds 1 and 4 (each within the scatter of the next); then compound 2. At a limit, above all of these: compound 3.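

In this assay, the step on an aromatic carbon of the five-membered aromatic ring with 3 nitrogen is a 1.1-fold higher number from compound 1 to compound 4 (0.02 log units; within the scatter) and shows that this position accepts 4-pentylphenyl in place of (((4-methylphenyl)sulfonyl)amino)methyl with no difference beyond the scatter. Within the data shown here, the hydrogen-bond donor and acceptors counted on the leaving group have no counterpart on the entering group, yet compound 1 and compound 4 stay within the scatter of each other. Compound 2 also carries an aryl group on that carbon and gives 57200 nM in this assay, so an aryl group there does not by itself set that number.

From the compounds shown here alone, whether an amine or a carboxylic acid on this carbon, or a longer chain in place of pentyl, would stay within this range remains open. The values shown give no cause for the step.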